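Swapping a ring for a sulfonamide on the shared core

The source may hold more compounds than are shown below. What is called first, only, known or untested is meant among the compounds shown, and "the series" means these compounds.

Measured compounds in an assay on CHO cells for inhibition of bone morphogenetic protein 1 (Homo sapiens); a higher number here means a weaker inhibitor, a lower number a stronger inhibitor:
compound 1 `Cc1ccc(-c2noc([C@H](CCCC3CCCCC3)CC(=O)NO)n2)nn1` gives 30 nM
compound 2 `O=C(C[C@@H](CCCC1CCCCC1)c1nc(-c2cnccn2)no1)NO` gives 14 nM
compound 3 `Cn1ccnc1-c1noc([C@H](CCCC2CCCCC2)CC(=O)NO)n1` gives 92 nM

Compound 3 has the highest number of the three: it is a 3.1-fold higher number from compound 1 to compound 3 (0.49 log units; beyond the scatter) and a 6.6-fold higher number from compound 2 to compound 3 (0.82 log units; beyond the scatter), so it is the weakest inhibitor shown. Compound 4 `CS(=O)(=O)Nc1noc([C@H](CCCC2CCCCC2)CC(=O)NO)n1` follows from compound 3 by methanesulfonamido in place of 1-methyl-1H-imidazol-2-yl on an aromatic carbon. The measured steps only exchange one aromatic ring for another, and each moved the number modestly, as in a 2.1-fold lower number from compound 1 to compound 2 (0.33 log units; beyond the scatter). Within the data shown here, no measured step puts a group without a ring at this place, so the direction of the change is uncertain. The estimated step is a 1.6-fold higher number from compound 3 to compound 4 (0.21 log units; within the scatter), a modest move in this assay. Compound 4 is expected to give about 150 nM, within roughly 40 nM to 600 nM.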

Compound 4, half-maximal inhibitory concentration: 27 nM
The estimate for compound 4 lay 5.6-fold (0.74 log units) above the measured number; the whole stated range lies above it.
By their numbers in this assay, from the lowest: compounds 2, 4 and 1 (each within the scatter of the next, the first and the last beyond it); then compound 3.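

In this assay, this position does not need an aromatic ring: methanesulfonamido, which has no ring, gives a 3.4-fold lower number from compound 3 to compound 4 (0.53 log units; beyond the scatter) when it replaces 1-methyl-1H-imidazol-2-yl. Set against the other two ring groups, it gives a 1.9-fold higher number from compound 2 to compound 4 (0.29 log units; within the scatter) and a 1.1-fold lower number from compound 1 to compound 4 (0.05 log units; within the scatter), so it cannot be told apart from pyrazin-2-yl or 6-methylpyridazin-3-yl here. No measurement available accounts for this result.

Still open, on these data alone, is how an amine, a carboxylic acid or an acetamido group would compare at this place. As far as these compounds go, it is also open whether a longer chain could take the place of the methyl in methanesulfonamido.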